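The source may hold more compounds than are shown below. What is called first, only, known or untested is meant among the compounds shown, and "the series" means these compounds.

Compound 1 `O=C(O)C1=Cc2ccccc2OC1(OCc1cc(-c2ccc([N+](=O)[O-])cc2)no1)C(F)(F)F` is the weaker of the two compounds with numbers in a functional assay on DU-145 cells (Homo sapiens) for inhibition, read by MTT assay, with a stated time of 24 h (a higher number here means a weaker inhibitor, a lower number a stronger inhibitor), where compound 1 gives 100000 nM. Its nearest neighbour is compound 3 `CCOC(=O)C1=Cc2ccccc2OC1(OCc1cn(-c2ccc(F)c(Cl)c2)nn1)C(F)(F)F`, which in this assay gives 21500 nM. Compound 2 `CCOC(=O)C1=Cc2ccccc2OC1(OCc1cc(-c2ccc([N+](=O)[O-])cc2)no1)C(F)(F)F` reaches only a limit of this assay, > 150000 nM, that is the limit of > 150000 nM in this assay, at which 1 of the 3 values shown sits. Within the data shown here, the one measured step, an at least 1.5-fold higher number from compound 1 to compound 2 (0.17 log units; that floor lies within the scatter), concerns the ester oxygen and does not touch the aryl group changed here. Compound 4 `O=C(O)C1=Cc2ccccc2OC1(OCc1cc(-c2cccc(C(F)(F)F)c2)no1)C(F)(F)F` differs from compound 1 by 3-(trifluoromethyl)phenyl in place of 4-nitrophenyl on an aromatic carbon. Among the measured compounds shown here, no measured step speaks to this change, so no step beyond the scatter is expected; the step from compound 1 to compound 4 in this assay is estimated as a 1.3-fold lower number from compound 1 to compound 4 (0.10 log units; within the scatter). Compound 4 is expected to give 80000 nM in this assay, within 30000 nM to 150000 nM.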

Compound 4, half-maximal inhibitory concentration: 155000 nM
Estimate against measurement, compound 4: 1.9-fold (0.29 log units) below, and the stated range ends below it.
By their numbers in this assay, from the lowest: compound 3; then compounds 1 and 4 (each within the scatter of the next).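

In this assay, among these compounds, 3-(trifluoromethyl)phenyl in place of 4-nitrophenyl gives a 1.6-fold higher number from compound 1 to compound 4 (0.19 log units; within the scatter), the only measured change of the aryl group at this position. Among the compounds shown here, the hydrogen-bond acceptors of 4-nitrophenyl have no counterpart in 3-(trifluoromethyl)phenyl, yet this exchange stays within the scatter. The comparison within this series is also bounded, since compound 2 stands only as a limit: the limit of > 150000 nM in this assay, at which 1 of the 4 values shown sits.

Still open, as far as these compounds go, is whether an amine or a hydroxyl group on this phenyl ring would shift the number beyond the scatter. The same holds for a methyl group replacing the whole aryl group.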